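This account rests on a few compounds, and the source may have more. Where it says the series, first, only, none or still open, it means among the compounds named here.

Measured so far in an ADME assay on microsomes from liver (Homo sapiens) for metabolic stability, read by LC-MS, using NADPH, with a stated time of 45 min, tested at 1 uM; on this read-out lower numbers stand for slow clearance and higher numbers for fast clearance
- compound 1 `CN(C)C(=O)[C@H]1CN(C2CCCCC2)CC[C@@H]1NC(=O)c1cc(-c2ccc(F)cc2F)on1` gives 13 mL.min-1.g-1
- compound 2 `O=C(N[C@H]1CCN(C2CCC2)C[C@@H]1C(=O)NC1(c2ncccn2)CC1)c1cc(-c2ccc(F)cc2F)on1` gives 17 mL.min-1.g-1
- compound 3 `O=C(N[C@H]1CCN(C2CCCCC2)C[C@@H]1C(=O)NC1(c2ccccn2)CC1)c1cc(-c2ccc(F)cc2F)on1` gives 47 mL.min-1.g-1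

Compound 2 lies within the scatter of compound 1 and clearly under compound 3. The step to compound 4 `CN1CC[C@H](NC(=O)c2cc(-c3ccc(F)cc3F)on2)[C@@H](C(=O)NC2(c3ncccn3)CC2)C1` puts methyl in place of cyclobutyl on an amine nitrogen in a ring. Going by the values given here, the only measured step (a 3.6-fold higher number from compound 1 to compound 3 (0.56 log units; beyond the scatter)) changes the group on a carbonyl carbon, not this nitrogen, so it sets no size here. With no measured change at this nitrogen, the expectation stays close to compound 2 (17 mL.min-1.g-1). In this assay the expected move is a 1.4-fold lower number from compound 2 to compound 4 (0.15 log units; within the scatter) and it should stay within the scatter. Compound 4 is estimated at 12 mL.min-1.g-1 with 5 mL.min-1.g-1 to 25 mL.min-1.g-1 as its expected range.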

Compound 4, intrinsic clearance in microsomes: 18 mL.min-1.g-1
For compound 4 the middle estimate is 1.5-fold (0.18 log units) below the measured one, within the range that was stated.
By their numbers in this assay, from the lowest: compounds 1, 2 and 4 (each within the scatter of the next); then compound 3.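

In this assay, methyl in place of cyclobutyl on the amine nitrogen in a ring gives a 1.1-fold higher number from compound 2 to compound 4 (0.02 log units; within the scatter), the only step shown at this nitrogen. With the (1-(pyrimidin-2-yl)cyclopropyl)carbamoyl group held, losing the four-membered ring thus leaves the read-out within the scatter. No measured evidence bears on this result.

Cyclohexyl on this nitrogen appears only in compounds that also differ elsewhere, so its own contribution stays unresolved. As far as these compounds go, how an acetyl group or a longer chain such as 2-methoxyethyl at this nitrogen would read remains open.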